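Losing a chloro group on the shared core of compound 2

The source may report more compounds than this note shows. Statements on the series, on what has been measured and on what is new or still open speak of the compounds shown alone.

This account follows two measured compounds and one that awaits its number. In a functional assay on SK-MEL-5 cells (Homo sapiens) for cytotoxicity, read by sulforhodamine B assay, with a stated time of 48 h (on this read-out higher numbers stand for weaker inhibition of growth and lower numbers for stronger inhibition of growth), compound 1 `ClCc1ccc(Cn2cnc3c(Cl)ncnc32)cc1` gives 3230 nM, while compound 2 `ClCc1ccccc1Cn1cnc2c(Cl)nc(Cl)nc21` gives 420 nM, the lower of the two numbers and, by what the two values show, the stronger growth inhibitor of the pair by a margin beyond the usual scatter. Compound 3 `ClCc1ccccc1Cn1cnc2c(Cl)ncnc21` keeps the core of compound 2 with one change: hydrogen in place of chloro on an aromatic carbon. Among the compounds with values here, no measured pair traces this exact change, so the step in this assay can only be anticipated. Given that compound 1, which also carries a single chloro on its core, gives 3230 nM, the expectation is a step of a 3.6-fold higher number from compound 2 to compound 3 (0.55 log units; beyond the scatter) toward weaker growth inhibition, of a size that probably exceeds the scatter but falls short of the gap between compound 2 and compound 1. Compound 3 is therefore estimated at 1500 nM, within a range from 450 nM to 5000 nM.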

Compound 3, concentration for 50% growth inhibition: 1410 nM
Estimate against measurement, compound 3: 1.1-fold (0.03 log units) above; the range from low to high includes it.
By their numbers in this assay, from the lowest: compound 2; then compound 3; then compound 1.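

Within the data shown here, the pair of compound 2 and compound 3 gives the first direct reading of this position: in this assay, hydrogen in place of chloro on the aromatic carbon between two ring nitrogen atoms gives a 3.4-fold higher number from compound 2 to compound 3 (0.53 log units; beyond the scatter), a modest step toward weaker growth inhibition that lies beyond the scatter. The chloro group at this carbon therefore contributes to the growth inhibition of compound 2, yet it is not essential, since compound 3 still gives 1410 nM without it. Nothing available accounts for the size of this step.

The compounds shown carry only chloro or hydrogen at this carbon. From the compounds shown here alone, whether an amine or a methoxy group there would match compound 2, or fall closer to compound 3, remains open.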